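Hexyl in Place of Isopropyl on a Shared Urea Core

The source may report more compounds than this note shows. Statements on the series, on what has been measured and on what is new or still open speak of the compounds shown alone.

Compound 1, `CCc1cccc(NC(=O)N[C@@H](C)c2ccccc2)c1`: 94% in an ADME assay on the whole organism with Oryza sativa as the target, tested at 1 uM; a higher number here means a weaker effect of the compound at the concentration tested, a lower number a stronger effect
Compound 2, `CC(C)c1ccc(NC(=O)N[C@H](C)c2ccccc2)cc1`: 79% in this assay

Of the compounds shown here, two have been measured so far, both built on the same urea core. Compound 2 stands lowest of the two numbers, meaning the stronger effect at the concentration tested. Its nearest neighbour is compound 1, whose value lies higher by a gap that is beyond the usual scatter of this kind of measurement, so the two results are genuinely different. No single-point comparison between them is available, because they differ in more than one place, so nothing more than the two values themselves can be read from them.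

The next compound, compound 3, is `CCCCCCc1ccc(NC(=O)N[C@H](C)c2ccccc2)cc1`. It is derived from compound 2 by one change: hexyl in place of isopropyl on an aromatic carbon. Within the data shown here, no measured pair in this set shows what such a lengthening of an alkyl chain does in this assay, so the direction of the step is open. The longer chain is expected to give at most a modest shift, probably downward, with a number 7 percentage points lower from compound 2 to compound 3 (within the scatter) as the expected step from compound 2 to compound 3. Compound 3 is therefore estimated at 72%, with a plausible range from 50% to 95%.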

Compound 3, a percentage reported as activity, at one concentration (the size of the read-out at that concentration, not a potency): 101%
For compound 3 the middle estimate is 29 percentage points below the measured one; measured number outside the range, above it.
By their numbers in this assay, from the lowest: compound 2; then compounds 1 and 3 (each within the scatter of the next).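

Among these compounds, this is the first pair in the set that differs in only one place, so it gives the first direct reading of this position: hexyl in place of isopropyl on an aromatic carbon, para to a large group, goes with a number 22 percentage points higher from compound 2 to compound 3 (beyond the scatter) in this assay. Since a higher number here means a weaker effect, compound 3 with its hexyl chain shows a weaker effect at the concentration tested than compound 2 with its isopropyl group. The position is therefore not indifferent to what sits on it, and a longer alkyl chain there does not strengthen the effect, at least for this one change. Nothing in the data at hand explains why the number moves this way.

Among the compounds shown here, with only two groups compared at this position, it remains open whether the number climbs gradually with chain length or whether a shorter straight chain such as butyl would already behave like hexyl. Going by these compounds, it is also open how a group of a different kind, such as an amine or a carboxylic acid, would read at this same position in this assay.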